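The source may hold more compounds than are shown below. What is called first, only, known or untested is meant among the compounds shown, and "the series" means these compounds.

Measured so far:
- compound 1 `CC(C)C(=O)NCCCc1cccc2c1C[C@@H](CCCCc1ccccc1)O2`: in an assay on NIH3T3 cells for binding affinity to melatonin receptor type 1A (Homo sapiens) (a lower number here means a stronger inhibitor, a higher number a weaker inhibitor), compound 1 gives 4 nM
- compound 2 `O=C(NC[C@@H]1C[C@H]1c1cccc2c1C[C@@H](CCCCc1ccccc1)O2)C1CC1`: in this assay compound 2 gives 1 nM

Compound 2 holds the lowest of the two numbers in this assay; the gap to compound 1 lies beyond the usual scatter, and the two compounds differ in more than one place, so no single step accounts for it.

Compound 3 `CCC(=O)NC[C@@H]1C[C@H]1c1cccc2c1C[C@@H](CCCCc1ccccc1)O2` differs from compound 2 by ethyl in place of cyclopropyl on a carbonyl carbon. Within the data shown here, no measured step of this kind exists. The change is expected to move this assay little, with any shift likely within the scatter and, if anything, toward a slightly higher number; the expected step is a 2.0-fold higher number from compound 2 to compound 3 (0.30 log units; within the scatter). For compound 3 the estimated value in this assay is 2 nM, with a range of 0.6 nM to 6 nM.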

Compound 3, inhibition constant: 1 nM
The estimate for compound 3 lay 2.0-fold (0.30 log units) above the measured number; the range from low to high includes it.
By their numbers in this assay, from the lowest: compounds 2 and 3 (each within the scatter of the next); then compound 1.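

Among these compounds, on a carbonyl carbon whose other neighbour is an amide-type nitrogen, ethyl in place of cyclopropyl gives no change at the digits printed from compound 2 to compound 3 (within the scatter) in this assay, so this ring is not needed to hold the number at this level. 2-((propanoylamino)methyl)cyclopropyl in place of 3-((isopropylcarbonyl)amino)propyl on an aromatic carbon gives a 4.0-fold lower number from compound 1 to compound 3 (0.60 log units; beyond the scatter), the only single-place step here beyond the scatter. No evidence on the origin of either step is available. Going by these compounds, how a longer chain such as butyl or an amine on this carbonyl carbon would read stays open. The step from compound 1 also remains unsplit between its cyclopropyl and its acyl parts.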